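The compounds below may be only part of what the source reports. "The series", "measured", "known", "first", "only" and "open" are said of these compounds alone.

Of the compounds shown here, two have numbers so far. Compound 1 `COc1ccc(-c2nc(-c3ccccc3)c(-c3ccc4c(c3)NC(=O)CO4)[nH]2)cc1` and compound 2 `COc1ccc(-n2cc(-c3ccccc3)c(-c3ccc4c(c3)NC(=O)CO4)n2)cc1` carry the same set of groups on closely related cores. In a functional assay on DLD-1 cells (Homo sapiens) for cytotoxicity, read by colorimetric assay and MTT assay, with a stated time of 3 days, tested at 20 uM (a higher number here means a weaker effect of the compound at the concentration tested, a lower number a stronger effect), compound 1 gives 19.1%. In this assay compound 2 gives 35.6%, the highest of the two numbers; the nearest is compound 1, whose number lies lower by more than the usual scatter. For the measured compounds named here, no pair of measured compounds differs in a single place, so no measured step is available to guide the next change. Compound 3 `Cc1ccccc1-n1cc(-c2ccccc2)c(-c2ccc3c(c2)NC(=O)CO3)n1` is the next to go into this assay. It differs from compound 2 in one place: 2-methylphenyl in place of 4-methoxyphenyl on an aromatic nitrogen. Nothing measured in this series shows what such an exchange does to the read-out. With only compound 2 as anchor, the expected step is a number 2.4 percentage points higher from compound 2 to compound 3 (within the scatter), in no clear direction and not beyond the scatter. For compound 3 the estimate in this assay is 38%, with an expected range from 20% to 60%.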

Compound 3, a percentage reported as activity, at one concentration (the size of the read-out at that concentration, not a potency): 62.9%
Compound 3: the middle estimate sits 24.9 percentage points below what was measured, and the stated range ends below it.
By their numbers in this assay, from the lowest: compound 1; then compound 2; then compound 3.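

In this assay, for the compounds shown here, 2-methylphenyl in place of 4-methoxyphenyl on the aromatic nitrogen gives a number 27.3 percentage points higher from compound 2 to compound 3 (beyond the scatter), the first single-place step, and it shows that the group on this nitrogen can move the read-out toward a weaker effect at the concentration tested. The exchange changes both the substituent on the phenyl ring and its place on that ring, and it also removes the one hydrogen-bond acceptor of the leaving group, so this single step cannot separate these changes. Nothing available explains the size of the step.

The compounds shown leave open whether the step follows the methyl group or its place on the ring, a question that a 4-methylphenyl or a 2-methoxyphenyl group on the same nitrogen would address directly. They also leave open how this position responds to an amine or a carboxylic acid on the phenyl ring, and whether the same exchange on the core of compound 1 gives a step of similar size and direction.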